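The compounds below may be only part of what the source reports. "The series", "measured", "known", "first", "only" and "open" are said of these compounds alone.

Of the compounds shown here, three that share one core have so far been measured in an ADME assay on Vero cells (Chlorocebus sabaeus) for cytotoxicity, with a stated time of 5 days; a higher number here means a weaker inhibitor, a lower number a stronger inhibitor. Compound 1 `O=C(/C=C/c1ccc(N2CCCCC2)cc1)c1ccsc1` gives 34400 nM. Compound 2 `Cc1ccsc1C(=O)/C=C/c1ccc(N2CCCCC2)cc1` gives 63900 nM, and compound 3 `Cc1ccc(C(=O)/C=C/c2ccc(N3CCCCC3)cc2)s1` gives 50500 nM. Compound 3 lies within the scatter of both of the others: a 1.5-fold higher number from compound 1 to compound 3 (0.17 log units; within the scatter), and a 1.3-fold lower number from compound 2 to compound 3 (0.10 log units; within the scatter). Compound 4 `O=C(/C=C/c1ccc(N2CCCCC2)cc1)c1ccc(Br)s1` has not yet been measured; it differs from compound 3 in one place: bromo in place of methyl on an aromatic carbon. Among the measured compounds shown here, the two steps already seen at this part of the structure both stayed within the scatter, and no step involving a bromo group has been measured, so nothing beyond the scatter is expected. For compound 4 the estimate in this assay is 50000 nM, within 20000 nM to 120000 nM. That estimate means an expected step of a 1.0-fold lower number from compound 3 to compound 4 (0.00 log units; within the scatter).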

Compound 4, half-maximal inhibitory concentration: 69500 nM
The estimate for compound 4 lay 1.4-fold (0.14 log units) below the measured number, and the stated range covers the measured number.
By their numbers in this assay, from the lowest: compounds 1, 3, 2 and 4 (each within the scatter of the next, the first and the last beyond it).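

In this assay bromo on the aromatic carbon next to the ring sulfur reads much like methyl there: the swap gives a 1.4-fold higher number from compound 3 to compound 4 (0.14 log units; within the scatter) and the change from the 3-methylthiophen-2-yl group gives a 1.1-fold higher number from compound 2 to compound 4 (0.04 log units; within the scatter), both within the scatter. Only a 2.0-fold higher number from compound 1 to compound 4 (0.31 log units; beyond the scatter) goes beyond the scatter, and modestly, in a step that replaces thiophen-3-yl with 5-bromothiophen-2-yl. On these data alone, whether an amine or a carboxylic acid on this same carbon would shift the number further remains open. So does whether a chloro group would match bromo. No measurement available here explains these numbers.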